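Swapping one fluorinated ring on the sulfonyl group

The compounds below may be only part of what the source reports. "The series", "measured", "known", "first", "only" and "open" are said of these compounds alone.

Compound 1, `O=S(=O)(c1cc(F)cc(F)c1)c1cnc2cc(F)ccc2c1-c1ccc(Cl)cc1`, is the starting point. In an ADME assay on microsomes from liver (Homo sapiens) for metabolic stability, tested at 2.5 uM (a higher number here means faster removal of the compound, a lower number slower removal), compound 1 gives 0.03 mL/min, the lowest of the three measured numbers. Compound 2, `O=S(=O)(c1cc(F)cc(F)c1)c1cnc2cc(F)ccc2c1-c1cccc(Cl)c1`, gives 0.22 mL/min, and compound 3, `COc1ccc(-c2c(S(=O)(=O)c3cc(F)cc(F)c3)cnc3cc(F)ccc23)cc1`, gives 1.51 mL/min. The measured steps all concern the ring attached to the aromatic carbon of the shared core: a 7.3-fold higher number from compound 1 to compound 2 (0.87 log units; beyond the scatter), a 50-fold higher number from compound 1 to compound 3 (1.70 log units; beyond the scatter), and a 6.9-fold higher number from compound 2 to compound 3 (0.84 log units; beyond the scatter).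

Compound 4, `O=S(=O)(c1ccc(F)cc1)c1cnc2cc(F)ccc2c1-c1ccc(Cl)cc1`, differs from compound 1 elsewhere: 4-fluorophenyl in place of 3,5-difluorophenyl on a sulfonyl sulfur. Going by the values given here, none of the measured steps touches the ring on the sulfonyl sulfur, so they do not bear on this change directly; they only show that this series can shift sharply when one ring is altered. Among the compounds with values here, removing one fluorine from that ring is a small change with no measured precedent here, so in this assay the expectation is a step no larger than the usual scatter, if anything a slightly higher number.

Compound 4 is therefore estimated at 0.05 mL/min, with a range from 0.02 mL/min to 0.15 mL/min. That estimate means an expected step of a 1.7-fold higher number from compound 1 to compound 4 (0.22 log units; within the scatter).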

Compound 4, intrinsic clearance in a liver preparation (reported as CLH), per the amount of preparation that the assay uses: 1.23 mL/min
Estimate against measurement, compound 4: 25-fold (1.39 log units) below, outside the stated range (above it).
By their numbers in this assay, from the lowest: compound 1; then compound 2; then compounds 4 and 3 (each within the scatter of the next).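

The ring on the sulfonyl sulfur turns out to matter as much as the ring changes already seen: in this assay, 4-fluorophenyl in place of 3,5-difluorophenyl gives a large step (a 41-fold higher number from compound 1 to compound 4 (1.61 log units; beyond the scatter)). Going by these compounds alone, that step belongs to the same large class as the change from chloro to methoxy (a 50-fold higher number from compound 1 to compound 3 (1.70 log units; beyond the scatter)), so the very low number of compound 1 depends on both of these rings, not only on the one the earlier steps explored. For this pair, a difference of a single fluorine on the ring at the sulfonyl sulfur is enough to move the number well beyond the scatter, yet nothing given here explains why.

On these data alone, it remains open whether the same change would produce a step of similar size with 3-chlorophenyl or 4-methoxyphenyl on the other ring, since this pair carries only 4-chlorophenyl there. Also open, as far as these compounds go, is how the number would respond to other groups on the sulfonyl sulfur, such as plain phenyl, 3-fluorophenyl or a pyridine ring, which would show whether the 3,5-difluorophenyl ring is unusual or merely one of several that give a low number.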